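Adding a hydroxy group to the chain of compound 1

A few compounds are considered here, and "the series" means these few. Any claim that something is new, unique, unknown or untested is made for them only; others in the source may bear on it.

Measured in a functional assay on ileum (Cavia porcellus) for antagonist activity; on this read-out lower numbers stand for stronger inhibition and higher numbers for weaker inhibition:
- Compound 1 `O=C(O)c1ccc(OCCCOc2ccc3c(O)c([N+](=O)[O-])c(=O)oc3c2)cc1`: > 20000 nM, a limit of the assay and not a number
- Compound 2 `CC(=O)c1ccc(OCCCOc2ccc3c(O)c([N+](=O)[O-])c(=O)oc3c2)cc1O`: 2800 nM

Compound 1 has no exact value and stands at the limit of > 20000 nM in this assay, at which 1 of the 2 values shown sits. Compound 3 `O=C(O)c1ccc(OCC(O)COc2ccc3c(O)c([N+](=O)[O-])c(=O)oc3c2)cc1` differs from it at one place on the chain: hydroxy in place of hydrogen on a saturated chain carbon bound to two saturated chain carbons. Among the compounds with values here, the only measured step is an at least 7.1-fold lower number from compound 1 to compound 2 (0.85 log units; beyond the scatter). That step swaps the 4-carboxyphenyl group, which compound 3 keeps, so it bears only indirectly on a change to the chain. Within the data shown here, no measured step covers this hydroxy, so no step beyond the scatter is expected in this assay, and neither direction is favoured. The estimated change is a number no higher from compound 1 to compound 3 (the limit leaves the size open). The expected value for compound 3 is 20000 nM, within an estimated range of 6000 nM to 60000 nM.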

Compound 3, half-maximal inhibitory concentration: > 10000 nM
Compound 3: a limit, no number; the forecaster's own chance of this, stated with the estimate: 60%; the middle value does not contradict the limit.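

Compound 1 and compound 3 each carry only a limit of the assay and not a number, so the step between them cannot be read. The compounds shown leave open whether this hydroxy on the chain changes inhibition at all, in either direction.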